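The compounds below may be only part of what the source reports. "The series", "measured", "known", "first", "only" and "open" are said of these compounds alone.

Compound 2, with the structure `N=C(N)c1ccc(-c2ccc(-c3nc4cc(C(=N)N)ccc4[nH]3)o2)cc1`, is the weakest of the three compounds measured in a functional assay on B16 cells (Mus musculus), with a stated time of 72 h; a higher number here means a weaker inhibitor, a lower number a stronger inhibitor. In this assay compound 2 gives 43200 nM, while compound 3, `c1ccc2[nH]c(-c3ccc(-c4ccc(C5=NCCN5)cc4)o3)nc2c1`, gives 8600 nM and compound 1, `COc1ccc(-c2ccc(-c3ccc(C4=NCCN4)cc3)o2)cc1`, gives 1700 nM. Both of those gaps lie beyond the scatter, so compound 2 stands clearly apart at the weak end.

Compound 4, `N=C(N)c1ccc2[nH]c(-c3ccc(-c4ccc(N)cc4)o3)nc2c1`, has not yet been measured. It differs from compound 2 in one place: one nitrogen atom in place of a group of 3 heavy atoms (1 carbon, 2 nitrogen; no ring), on an aromatic carbon. The change sits on an aromatic carbon of a six-membered aromatic ring of carbon only, para to a large group.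

For the measured compounds named here, no measured pair shows this particular change, so its effect is not known from these data. Compound 3 and compound 1, which carry no amidine on the phenyl end, both give lower numbers than compound 2, so a modest gain is expected for compound 4, though one that may not exceed the scatter. Compound 4 is expected to give about 20000 nM, within a range from 5000 nM to 80000 nM, a step of a 2.2-fold lower number from compound 2 to compound 4 (0.33 log units; beyond the scatter).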

Compound 4, half-maximal inhibitory concentration: > 100000 nM
Compound 4 was reported as a limit; the forecaster's own chance of this, stated with the estimate: 10%; middle value at least 5.0-fold (0.69 log units) from the limit.
By their numbers in this assay, from the lowest: compound 1; then compound 3; then compound 2. At a limit, above all of these: compound 4.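

For the compounds shown here, on the shared core, this change gives the first single-place comparison at this aromatic carbon, and it goes toward weaker inhibition: amino in place of the group of 3 heavy atoms (1 carbon, 2 nitrogen; no ring) gives an at least 2.3-fold higher number from compound 2 to compound 4 (0.36 log units; beyond the scatter). So in this assay this carbon does not tolerate the swap without loss, a point the earlier compounds, which share no single-place step, could not show. Compound 4 is reported only as a limit: the limit of > 100000 nM in this assay, at which 1 of the 4 values shown sits.

From the compounds shown here alone, the true size of the step therefore stays open, since the printed figure gives only its lower bound. Also open, going by these compounds, is how a carboxylic acid or a longer chain on this same carbon would read in this assay, and whether amino would have the same effect on another core.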